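Nitrile in Place of Nitro on the Cinnamamide Aryl

The source may hold more compounds than are shown below. What is called first, only, known or untested is meant among the compounds shown, and "the series" means these compounds.

Compound 1 `O=C(/C=C/c1ccc([N+](=O)[O-])cc1)Nc1cc2c(Nc3ccc(F)c(Cl)c3)ncnc2cc1O[C@H]1CCOC1` in a functional assay on PC-3 cells (Homo sapiens) for cytotoxicity, read by MTT assay, with a stated time of 72 h (on this read-out higher numbers stand for weaker inhibition and lower numbers for stronger inhibition), gives 22800 nM. Compound 2 `COc1cc(/C=C/C(=O)Nc2cc3c(Nc4ccc(F)c(Cl)c4)ncnc3cc2O[C@H]2CCOC2)cc(OC)c1O` gives 26500 nM, and compound 3 `COc1cc(/C=C/C(=O)Nc2cc3c(Nc4ccc(F)c(Cl)c4)ncnc3cc2O[C@H]2CCOC2)cc(OC)c1` gives 25600 nM. Compound 1 has the lowest of the three numbers, yet a 1.2-fold higher number from compound 1 to compound 2 (0.07 log units; within the scatter) and a 1.1-fold higher number from compound 1 to compound 3 (0.05 log units; within the scatter) are both within the scatter, as is a 1.0-fold lower number from compound 2 to compound 3 (0.02 log units; within the scatter), so the three stand together. Compound 4 `N#Cc1ccc(/C=C/C(=O)Nc2cc3c(Nc4ccc(F)c(Cl)c4)ncnc3cc2O[C@H]2CCOC2)cc1` differs from compound 1 by cyano in place of nitro on an aromatic carbon. For the measured compounds named here, the steps that bear on this are the two swaps of the aryl group on the same chain, which changed the number only within the scatter. The author therefore expects no step beyond the scatter in this assay, with a 1.0-fold higher number from compound 1 to compound 4 (0.00 log units; within the scatter). Compound 4 is estimated at 23000 nM, between 12000 nM and 45000 nM.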

Compound 4, half-maximal inhibitory concentration: 36600 nM
Beside the measured number, compound 4's estimate is 1.6-fold (0.20 log units) below it, and the stated range covers the measured number.
By their numbers in this assay, from the lowest: compounds 1, 3, 2 and 4 (each within the scatter of the next).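

With cyano in place of nitro, the 4-cyanophenyl compound stays within the scatter of all three earlier compounds in this assay (a 1.6-fold higher number from compound 1 to compound 4 (0.21 log units; within the scatter); a 1.4-fold higher number from compound 3 to compound 4 (0.16 log units; within the scatter); a 1.4-fold higher number from compound 2 to compound 4 (0.14 log units; within the scatter)). The four aryl groups shown therefore do not separate on this read-out, and the change from nitro to cyano on this aromatic carbon gives no step beyond the scatter. Nothing available accounts for this result. The compounds shown leave open whether an amine or a carboxylic acid on this ring, or a longer chain in place of the 2-(4-cyanophenyl)ethenyl group, would give a step beyond the scatter.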